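This account rests on a few compounds, and the source may have more. Where it says the series, first, only, none or still open, it means among the compounds named here.

Among the measured compounds shown here, compound 2 `Clc1cccc(-c2nnc(C(NCc3ccccc3)c3ccc[nH]3)o2)c1`, with a value of 41100 nM in a functional assay on HT-1080 cells (Homo sapiens) for cytotoxicity, read by MTT assay, with a stated time of 24 h (a lower number here means a stronger inhibitor, a higher number a weaker inhibitor), stands second highest of the three numbers measured so far: compound 3 `Clc1ccc(-c2nnc(C(NCc3ccccc3)c3ccc[nH]3)o2)cc1` gives 41000 nM, and compound 1 `c1ccc(CNC(c2ccc[nH]2)c2nnc(-c3ccccc3)o2)cc1` gives 231000 nM. The change to compound 4 `Cc1ccc(-c2nnc(C(NCc3ccccc3)c3ccc[nH]3)o2)cc1` is 4-methylphenyl in place of 3-chlorophenyl on an aromatic carbon. Two kinds of measured step bear on it. The step of a 5.6-fold lower number from compound 1 to compound 2 (0.75 log units; beyond the scatter) and the step of a 5.6-fold lower number from compound 1 to compound 3 (0.75 log units; beyond the scatter) show that adding chloro lowers the number, whereas a 1.0-fold lower number from compound 2 to compound 3 (0.00 log units; within the scatter) shows that exchanging one chlorophenyl for the other makes no difference beyond the scatter. For the measured compounds named here, no measured step exchanges chloro for methyl, so the outcome is open. Compound 4 is therefore expected to come in near 70000 nM, within 20000 nM to 200000 nM. That estimate means an expected step of a 1.7-fold higher number from compound 2 to compound 4 (0.23 log units; within the scatter).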

Compound 4, half-maximal inhibitory concentration: 909000 nM
Compound 4: the middle estimate sits 13-fold (1.11 log units) below what was measured; the measured number lies above the stated range.
By their numbers in this assay, from the lowest: compounds 3 and 2 (each within the scatter of the next); then compound 1; then compound 4.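

In this assay, the choice of substituent on this phenyl group matters far more than the two chlorophenyl compounds could show: 4-methylphenyl gives a much higher number than either 3-chlorophenyl (a 22-fold higher number from compound 2 to compound 4 (1.34 log units; beyond the scatter)) or 4-chlorophenyl (a 22-fold higher number from compound 3 to compound 4 (1.35 log units; beyond the scatter)). Methyl also moves the number in the opposite direction from chloro when each replaces hydrogen (a 3.9-fold higher number from compound 1 to compound 4 (0.59 log units; beyond the scatter)). No measurement given here accounts for this difference between methyl and chloro. The compounds shown leave open how fluoro, an amine or a carboxylic acid in place of chloro would compare.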